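The compounds below may be only part of what the source reports. "The series", "measured", "known", "first", "only" and "open" are said of these compounds alone.

Compound 1 `COc1ccc(/C=C/C(=O)c2ccc(Nc3cc(C)nc4nc(SCc5nc6ccccc6[nH]5)nn34)cc2)cc1F`: 140 nM
Compound 2 `Cc1cc(Nc2ccc(C(=O)/C=C/c3ccccc3)cc2)n2nc(SCc3nc4ccccc4[nH]3)nc2n1`: 130 nM

In a functional assay on SW-620 cells (Homo sapiens) for cytotoxicity, read by MTT assay, with stated times of 4 h and 72 h, tested at 2 uM (on this read-out lower numbers stand for stronger inhibition and higher numbers for weaker inhibition), compound 2 gives 130 nM and compound 1 gives 140 nM. The two are effectively level, so compound 2 stands alongside compound 1 rather than ahead of it.

Compound 3 `Cc1cc(Nc2ccc(C(=O)/C=C/c3ccc(C(F)(F)F)cc3)cc2)n2nc(SCc3nc4ccccc4[nH]3)nc2n1` differs from compound 2 in one place, with trifluoromethyl in place of hydrogen on an aromatic carbon, para to a large group (trifluoromethyl in place of hydrogen on an aromatic carbon).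

Among the compounds with values here, only one measured step bears on this change. Swapping 3-fluoro-4-methoxyphenyl for phenyl alters the same aromatic ring, and that step, a 1.1-fold lower number from compound 1 to compound 2 (0.03 log units; within the scatter), was very small. It is thin evidence: a single pair, and neither compound carries trifluoromethyl. Within the data shown here, still, the one change seen on this ring left the number essentially unmoved, so no clear shift in either direction is expected here. The expected change is a 1.1-fold higher number from compound 2 to compound 3 (0.03 log units; within the scatter), which means no real difference is anticipated.

For compound 3, the estimated value is 140 nM, with an expected range of 50 nM to 400 nM.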

Compound 3, half-maximal inhibitory concentration: 1850 nM
Compound 3: middle estimate off by 13-fold (1.12 log units), on the low side; measured number outside the range, above it.
By their numbers in this assay, from the lowest: compounds 2 and 1 (each within the scatter of the next); then compound 3.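

In this assay this ring position proves far from indifferent: placing trifluoromethyl on the plain phenyl ring gives a 14-fold higher number from compound 2 to compound 3 (1.15 log units; beyond the scatter) and so weakens inhibition clearly, while the earlier swap on the same ring, a 1.1-fold lower number from compound 1 to compound 2 (0.03 log units; within the scatter), left the two compounds level. The comparison with the 3-fluoro-4-methoxyphenyl ring points the same way, with a 13-fold higher number from compound 1 to compound 3 (1.12 log units; beyond the scatter) showing that a substituted ring is not poorly tolerated as such, since one substituted ring stays level with phenyl and the 4-(trifluoromethyl)phenyl ring does not. Nothing available here accounts for this drop.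

The compounds shown leave open whether the loss is specific to trifluoromethyl or would appear with other single groups on this aromatic carbon, such as a lone fluorine, a lone methoxy group or an amine. Within the data shown here, with only one group tested alone at this place, they also cannot show whether any single group there can match plain phenyl or improve on it.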